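A few compounds are considered here, and "the series" means these few. Any claim that something is new, unique, unknown or untested is made for them only; others in the source may bear on it.

Measured so far in an assay for inhibition of arginase-1 (Homo sapiens), read by scintillation counting, with a stated time of 5 min, tested at 200 uM; a lower number here means less inhibition, a higher number more inhibition at the concentration tested (going by the name of the read-out):

Compound 1 `Cc1cc(=O)c(O)c(C(=O)O)o1` gives 8%.
Compound 2 `Cc1cc(C(=O)O)c(O)c(=O)[nH]1` gives 8%.
Compound 3 `CNC(=O)c1oc(C)cc(=O)c1O` gives 8%.

Compound 3 arises from compound 1 by one change, (methylamino in place of hydroxy on a carbonyl carbon). The step this made in this assay was no change at the digits printed from compound 1 to compound 3 (within the scatter). Compound 2 rests on a different core; the difference between the two cores is not broken down here. Its result sits level with those of compound 1 and compound 3, so all three show only slight inhibition.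

Compound 4 `CNC(=O)c1cc(C)[nH]c(=O)c1O` has not yet been measured. It arises from compound 2 by methylamino in place of hydroxy on a carbonyl carbon, the same change at the same place as before. For compound 4 the expected step in this assay is no change at the digits printed from compound 2 to compound 4 (within the scatter), because no change at the digits printed from compound 1 to compound 3 (within the scatter) came from this very change on a compound that starts at the same low level. Compound 4 is therefore expected to give about 8%, most likely between 0% and 20%.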

Compound 4, a percentage reported as inhibition, at one concentration (the size of the read-out at that concentration, not a potency): 5%
Estimate against measurement, compound 4: 3 percentage points above; the measured number falls inside the stated range.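

In this assay, putting methylamino in place of hydroxy on a carbonyl carbon, which turns carboxy into methylcarbamoyl, gave a number 3 percentage points lower from compound 2 to compound 4 (within the scatter). On the two cores shown, the change behaves alike: the same change on two cores in this assay, no change at the digits printed (within the scatter) from compound 1 to compound 3 and a number 3 percentage points lower (within the scatter) from compound 2 to compound 4, 3 percentage points apart, within the scatter of two such steps

This does not show that the change carries over in general, since all four compounds show only slight inhibition, and agreement at so low a level says little about how the change would act on a compound with strong inhibition.

The compounds shown leave open what a longer chain, such as ethylamino, or a cyclic amine, such as morpholine, would do on this carbonyl carbon. They also leave open whether any group there can lift inhibition clear of this low level.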